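Swapping the fused ring isomer on the exocyclic carbon

This account rests on a few compounds, and the source may have more. Where it says the series, first, only, none or still open, it means among the compounds named here.

Measured so far:
Compound 1, `CCOC(=O)C1=C(Nc2ccccc2)S/C(=C\c2ccc(C(=O)O)cc2)C1=O`, gives < 10% in a functional assay on MCF7 cells (Homo sapiens) for inhibition, read by MTT assay, with a stated time of 72 h, tested at 10 uM; a higher number here means more inhibition at the concentration tested (going by the name of the read-out), a lower number less inhibition; this is a limit of the assay rather than a number.
Compound 2, `CCOC(=O)C1=C(Nc2ccccc2)S/C(=C\c2ccc[nH]2)C1=O`, gives 18.3% in this assay.
Compound 3, `CCOC(=O)C1=C(Nc2ccccc2)S/C(=C\c2cc3cccnc3[nH]2)C1=O`, gives 18.2% in this assay.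

Compound 3 therefore sits at the lower of the two numbers, with compound 2 as its nearest neighbour; the gap a number 0.1 percentage points lower from compound 2 to compound 3 (within the scatter) lies within the scatter. The third value, that of compound 1, is only a limit (the limit of < 10% in this assay, at which 1 of the 3 values shown sits).

Compound 4, `CCOC(=O)C1=C(Nc2ccccc2)S/C(=C\c2cc3ccncc3[nH]2)C1=O`, has the same atoms as compound 3, joined differently: a group of 9 heavy atoms (7 carbon, 2 nitrogen; one five-membered aromatic ring with 1 hetero atom, one six-membered aromatic ring with 1 hetero atom) in place of a group of 9 heavy atoms (7 carbon, 2 nitrogen; one five-membered aromatic ring with 1 hetero atom, one six-membered aromatic ring with 1 hetero atom), on a double-bonded chain carbon bound to a double-bonded ring carbon.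

Within the data shown here, no measured step swaps two such isomers. The step that comes closest, a number 0.1 percentage points lower from compound 2 to compound 3 (within the scatter), replaced the five-membered ring by the fused two-ring group and moved nothing beyond the scatter, and a number at least 8.2 percentage points higher from compound 1 to compound 3 (that floor lies within the scatter) only set a floor within the scatter. A step of no size beyond the scatter is therefore expected for a number 0.2 percentage points lower from compound 3 to compound 4 (within the scatter). Compound 4 is estimated at 18%, between 8% and 30%.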

Compound 4, a percentage reported as inhibition, at one concentration (the size of the read-out at that concentration, not a potency): 18.2%
Estimate against measurement, compound 4: 0.2 percentage points below; measured number inside the range.
By their numbers in this assay, from the lowest: compounds 3, 4 and 2 (each within the scatter of the next). At a limit, below all of these: compound 1.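

Among these compounds, this is the first direct swap of two isomeric fused groups on the double-bonded chain carbon, and in this assay the result is no change at the digits printed from compound 3 to compound 4 (within the scatter), so within these two compounds, how the same atoms are joined in the fused group does not move the reading beyond the scatter. Set against the smaller 1H-pyrrol-2-yl group, the second fused group gives a number 0.1 percentage points lower from compound 2 to compound 4 (within the scatter), which repeats for a new isomer what the earlier fused compound showed. Compound 1 stands at a limit of the assay, so the comparison reads only as a number at least 8.2 percentage points higher from compound 1 to compound 4 (that floor lies within the scatter): the limit of < 10% in this assay, at which 1 of the 4 values shown sits.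

As far as these compounds go, whether an amine or a longer chain on the fused group would move the reading beyond the scatter stays open. A reading at one concentration also leaves the potency of these compounds unknown.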